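This account rests on a few compounds, and the source may have more. Where it says the series, first, only, none or still open, it means among the compounds named here.

Measured so far in a functional assay on COLO 205 cells (Homo sapiens) for antiproliferative activity, read by MTT assay; on this read-out lower numbers stand for stronger inhibition and higher numbers for weaker inhibition:
compound 1 `CCOC(=O)N1CCCc2cc(S(=O)(=O)N3CC(c4ccccc4)NC3=O)ccc21` — 2780 nM
compound 2 `O=C1NC(c2ccccc2)CN1S(=O)(=O)c1ccc2c(c1)CCCN2C(=O)C(F)(F)F` — 10700 nM

Compound 1 gives the lowest of the two numbers seen in this assay. Among the compounds with values here, the one measured step, a 3.8-fold higher number from compound 1 to compound 2 (0.59 log units; beyond the scatter), involves the same carbonyl carbon but a different entering group. Compound 3 `NC(=O)N1CCCc2cc(S(=O)(=O)N3CC(c4ccccc4)NC3=O)ccc21` differs from compound 1 by amino in place of ethoxy on a carbonyl carbon. That step offers only a loose guide, so he expects a step of a 1.3-fold higher number from compound 1 to compound 3 (0.10 log units; within the scatter) in this assay, a small shift toward weaker inhibition at most, and estimates compound 3 at 3500 nM, within 1200 nM to 10000 nM.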

Compound 3, half-maximal inhibitory concentration: > 20000 nM
Compound 3: no number, only a limit (the forecaster's own chance of this, stated with the estimate: 5%); middle value at least 5.7-fold (0.75 log units) from the limit.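

In this assay compound 3 gives only a limit, not a number: the limit of > 20000 nM in this assay, at which 1 of the 3 values shown sits. At this carbonyl carbon, amino in place of ethoxy brings an at least 7.1-fold higher number from compound 1 to compound 3 (0.85 log units; beyond the scatter), so ethoxy now leads over both entering groups shown, and the change from ethoxycarbonyl to carbamoyl is not tolerated as the ethoxy compound is. The other step reads an at least 1.8-fold higher number from compound 2 to compound 3 (0.27 log units; that floor lies within the scatter), which leaves the order of those two compounds unsettled.

From the compounds shown here alone, the true value of compound 3 stays open. So does whether a longer chain such as propoxy, or a methylamino group, on this carbonyl carbon would match or pass compound 1.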